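The source may hold more compounds than are shown below. What is called first, only, known or untested is meant among the compounds shown, and "the series" means these compounds.

Measured in a functional assay on CCRF-CEM cells (Homo sapiens) for cytotoxicity, in the presence of a further agent that is not named here; on this read-out lower numbers stand for stronger inhibition and higher numbers for weaker inhibition:
- compound 1 `COC(=O)c1ccc(CN(CCCc2c(N)nc(N)nc2O)c2cc(F)cc(F)c2[N+](=O)[O-])cc1`: > 100000 nM
- compound 2 `CC(C)(C)OC(=O)CCC(Nc1ccc(CN(CCCc2c(N)nc(N)nc2O)c2ccc([N+](=O)[O-])c(F)c2[N+](=O)[O-])cc1)C(=O)OC(C)(C)C`: 4000 nM
- compound 3 `CC(C)(C)OC(=O)CCC(Nc1ccc(CN(CCCc2c(N)nc(N)nc2O)c2cc(F)c([N+](=O)[O-])cc2[N+](=O)[O-])cc1)C(=O)OC(C)(C)C`: 1800 nM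

Compound 1 stands at the limit of > 100000 nM in this assay, at which 1 of the 3 values shown sits, so its entry is a limit of the assay and not a number. For the measured compounds named here, compound 2 gives 4000 nM and compound 3 gives 1800 nM, and these are the only two numbers in the set. Going by the values given here, no pair of measured compounds differs in a single place, so no measured step is available to guide the next change.

The next compound is compound 4 `Nc1nc(N)c(CCCNc2cc(F)cc(F)c2[N+](=O)[O-])c(O)n1`, not yet measured in this assay. The change from compound 1 is hydrogen in place of 4-(methoxycarbonyl)benzyl on a nitrogen on an aromatic ring, with hydrogen in place of 4-(methoxycarbonyl)benzyl on a nitrogen on an aromatic ring.

Compound 1 offers only a limit as its starting point, > 100000 nM, so the expectation is weakly grounded. No step beyond the scatter is expected in this assay, and compound 4 may well also be reported only as a limit. The expected change is a number no higher from compound 1 to compound 4 (the limit leaves the size open).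

Compound 4 is estimated at 100000 nM, with an expected range of 30000 nM to 200000 nM.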

Compound 4, half-maximal inhibitory concentration: 94000 nM
Compound 4: the middle estimate sits 1.1-fold (0.03 log units) above what was measured; low and high end bracket the measured number.
By their numbers in this assay, from the lowest: compound 3; then compound 2; then compound 4. At a limit, above all of these: compound 1.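

In this assay, hydrogen can now be set against 4-(methoxycarbonyl)benzyl on this nitrogen, and the change gives an at least 1.0-fold lower number from compound 1 to compound 4 (0.02 log units; that floor lies within the scatter). Compound 4 gives 94000 nM, which is a number and so provides a measured value for the form of this series with only hydrogen at this place. The value of compound 1 is a limit of the assay. No step beyond the scatter can be claimed for this change, and its true size stays unreadable because one end of the comparison is a limit: the limit of > 100000 nM in this assay, at which 1 of the 4 values shown sits.

From the compounds shown here alone, it remains open whether another group on this nitrogen, such as a plain benzyl, a small alkyl chain or a benzyl carrying a free carboxylic acid, would give a number clearly different from that of compound 4. Compound 2 and compound 3 differ from compound 4 in more than one place, so their values cannot be tied to any single change, and the steps among these compounds cannot be read.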